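This account rests on a few compounds, and the source may have more. Where it says the series, first, only, none or still open, it means among the compounds named here.

Measured so far
Compound 1, `CC(C)(C)OC(=O)NCC1CCCN(C(=O)CN2CN(c3ccccc3)C3(CCN(C(=O)c4ccc(C5CCCCC5)cc4)CC3)C2=O)C1`: in an assay on HEK293 cells for displacement of a labelled ligand from NPC1-like intracellular cholesterol transporter 1 (Homo sapiens) (a higher number here means a weaker inhibitor, a lower number a stronger inhibitor), compound 1 gives 3800 nM.
Compound 2, `CC(C)(C)c1ccc(C(=O)N2CCC3(CC2)C(=O)N(CC(=O)NCCC(=O)O)CN3c2ccccc2)cc1`: in this assay compound 2 gives 11400 nM.

Compound 2 stands at the higher of the two numbers on hand; compound 1 lies below it by a gap that is beyond the usual scatter. Among the compounds with values here, the two differ in more than one place, so no single structural step connects them, and their values say only that compound 1 is the stronger of the pair in this assay.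

The next compound is compound 3, `CC(C)(C)c1ccc(C(=O)N2CCC3(CC2)C(=O)N(CC(=O)NCCCNS(C)(=O)=O)CN3c2ccccc2)cc1`. It is compound 2 with one change:
(methanesulfonamido)methyl in place of carboxy on a saturated chain carbon, two bonds along the chain from an amide-type nitrogen
Within the data shown here, no step between measured compounds bears on this change, so there is no measured precedent here. The expectation is a modest drop in the number, of a size that may or may not clear the scatter: the estimated step from compound 2 to compound 3 in this assay is a 2.1-fold lower number from compound 2 to compound 3 (0.32 log units; beyond the scatter). On that basis compound 3 is expected to give about 5500 nM in this assay, within a range from 1800 nM to 17000 nM.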

Compound 3, half-maximal inhibitory concentration: 10400 nM
Beside the measured number, compound 3's estimate is 1.9-fold (0.28 log units) below it; the range from low to high includes it.
By their numbers in this assay, from the lowest: compound 1; then compounds 3 and 2 (each within the scatter of the next).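

In this assay, within the data shown here, the exchange of carboxy for (methanesulfonamido)methyl, on a saturated chain carbon, two bonds along the chain from an amide-type nitrogen, reads as a 1.1-fold lower number from compound 2 to compound 3 (0.04 log units; within the scatter) and gives the first single-place comparison. The two end groups cannot be told apart in this read-out, even though the group goes from 3 heavy atoms to 6 and brings in a sulfur, so replacing the carboxy leaves no mark on the number for this pair. No measurement on hand explains why the two end groups read alike.

As far as these compounds go, whether any group at this place moves the number remains open, since a single pair cannot show this: a primary amine, a primary carboxamide, or a shorter or longer chain ending in a carboxylic acid could each test it. Also open, from the compounds shown here alone, is whether the same exchange would read alike on the core of compound 1, and which of the several differences between that compound and the other two carries its separation from them.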